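Dropping one methoxy from a trimethoxy chalcone analogue

A few compounds are considered here, and "the series" means these few. Any claim that something is new, unique, unknown or untested is made for them only; others in the source may bear on it.

Compound 1 `O=C(/C=C/c1cn(-c2ccccc2)nc1-c1ccsc1)c1ccccc1`: in a functional assay on Huh-7 cells (Homo sapiens) for inhibition, read by sulforhodamine B assay, with a stated time of 72 h (a lower number here means a stronger inhibitor, a higher number a weaker inhibitor), compound 1 gives 4700 nM
Compound 2 `COc1cc(C(=O)/C=C/c2cn(-c3ccccc3)nc2-c2ccsc2)cc(OC)c1OC`: compound 2 gives 3600 nM
Compound 3 `COc1ccc(C(=O)/C=C/c2cn(-c3ccccc3)nc2-c2ccsc2)c(OC)c1OC`: compound 3 gives 4200 nM

All three share the same core and differ only in the methoxy groups on the ring attached to the carbonyl. Their numbers sit close together: compound 3 lies within the scatter of both compound 1 and compound 2, so none can be called stronger or weaker. Compound 4 `COc1ccc(C(=O)/C=C/c2cn(-c3ccccc3)nc2-c2ccsc2)cc1OC` is the next step: hydrogen in place of methoxy on an aromatic carbon. Since the methoxy count has made no difference beyond the scatter among compounds 1 to 3, a step from compound 3 to compound 4 of a 1.1-fold higher number from compound 3 to compound 4 (0.03 log units; within the scatter) is expected, no change beyond the scatter. Compound 4 is estimated at 4500 nM, between 2000 nM and 10000 nM.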

Compound 4, half-maximal inhibitory concentration: 2900 nM
Compound 4: the middle estimate sits 1.6-fold (0.19 log units) above what was measured, within the range that was stated.
By their numbers in this assay, from the lowest: compounds 4, 2, 3 and 1 (each within the scatter of the next).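

In this assay hydrogen in place of methoxy on an aromatic carbon, ortho to a large group, stays within the scatter (a 1.4-fold lower number from compound 3 to compound 4 (0.16 log units; within the scatter)), and so does the same swap at a different carbon (a 1.2-fold lower number from compound 2 to compound 4 (0.09 log units; within the scatter)). 3,4-Dimethoxyphenyl in place of phenyl on a carbonyl carbon also stays within it (a 1.6-fold lower number from compound 1 to compound 4 (0.21 log units; within the scatter)). This position can therefore lose its methoxy without a readable change, and all four compounds remain inseparable.

As far as these compounds go, whether an amine or a carboxylic acid here would move the number beyond the scatter stays open. Nothing measured on these compounds accounts for this flat result.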